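Pyridinyl Amide Variant of an Inactive Difluorophenyl Analogue

A few compounds are considered here, and "the series" means these few. Any claim that something is new, unique, unknown or untested is made for them only; others in the source may bear on it.

Measured compounds:
Compound 1, `O=C(Nc1ccc(-c2cc(C(F)(F)F)ccc2Cl)cc1)c1c(F)cccc1F`: 8 nM
Compound 2, `Cc1c(C2=NOC(C)(C)C2=O)cccc1-c1cnc(NC(=O)c2c(F)cccc2F)cn1`: 55 nM
Compound 3, `Cc1ccc(C2=NOC(C)(C)C2=O)cc1-c1cnc(NC(=O)c2ccc(F)cc2F)cn1`: "not active" (no number reported)

Of the compounds shown here, three have been tested in an assay on Jurkat T cells for inhibition of interleukin-2 (Homo sapiens), read by ELISA, with stated times of 10 min and 24 h; on this read-out higher numbers stand for weaker inhibition and lower numbers for stronger inhibition. Compound 1 gives 8 nM, and compound 2 gives 55 nM. Compound 3 shares the core of compound 2 but carries a 2,4-difluorophenyl group on the carbonyl carbon. In this assay compound 3 is reported as "not active" (no number reported), so no single number marks where it stands; it can only be said to sit apart from the two compounds that do carry a number.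

Compound 4, `Cc1ccc(C2=NOC(C)(C)C2=O)cc1-c1cnc(NC(=O)c2ccncc2)cn1`, has not yet been measured. It differs from compound 3 in one place: pyridin-4-yl in place of 2,4-difluorophenyl on a carbonyl carbon.

Among the compounds with values here, no step between measured compounds is known for this kind of change, and compound 3 itself has no number to step from. The account of compound 3 in this assay gives no ground to expect that compound 4 would move far into the range of compound 1 or compound 2; the likeliest outcome is that compound 4 again gives a weak result or only a limit, with a wide range of uncertainty.

Compound 4 is therefore expected to give 5000 nM in this assay, with a range from 300 nM to 50000 nM.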

Compound 4, half-maximal inhibitory concentration: "not active" (no number reported)
No number was reported for compound 4, so the estimate cannot be set against anything.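

In this assay compound 3 and compound 4 are both reported as not active, with no number for either, so no step can be read from the change of 2,4-difluorophenyl to pyridin-4-yl. The compounds shown leave open whether this change on the carbonyl carbon alters inhibition at all. No supporting evidence bears on this result.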